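Swapping the cyanophenyl arm for a tolyl group

The compounds below may be only part of what the source reports. "The series", "measured", "known", "first", "only" and "open" are said of these compounds alone.

Compound 1 `Cc1cc(-c2ccc(C#N)cc2)cc(C)c1Nc1ccnc(Nc2ccc(C#N)cc2)n1` is the starting point. In an ADME assay on MT4 cells (Homo sapiens) for cytotoxicity, read by MTT assay, with a stated time of 4 days (on this read-out higher numbers stand for lower toxicity in this test and lower numbers for higher toxicity in this test), compound 1 gives 2080 nM, and this is the smallest number among the three measured, though the other two are not separated from it beyond the scatter. Compound 2 `Cc1cc(-c2ccccc2)cc(C)c1Nc1ccnc(Nc2ccc(C#N)cc2)n1` gives 4170 nM, a change of a 2.0-fold higher number from compound 1 to compound 2 (0.30 log units; within the scatter). Compound 3 `Cc1cc(C)cc(-c2cc(C)c(Nc3ccnc(Nc4ccc(C#N)cc4)n3)c(C)c2)c1` gives 4140 nM, a change of a 2.0-fold higher number from compound 1 to compound 3 (0.30 log units; within the scatter). Compound 4 `Cc1ccccc1-c1cc(C)c(Nc2ccnc(Nc3ccc(C#N)cc3)n2)c(C)c1` has not yet been measured; the change from compound 1 is 2-methylphenyl in place of 4-cyanophenyl on an aromatic carbon. The two steps that bear on it, removing the cyano group and exchanging the whole ring, each gave only a shift inside the scatter, so no step beyond the scatter is expected here, with perhaps a slight rise. The expected step is a 1.7-fold higher number from compound 1 to compound 4 (0.23 log units; within the scatter). Compound 4 is estimated at 3500 nM, within 1500 nM to 8000 nM.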

Compound 4, half-maximal cytotoxic concentration: 3820 nM
For compound 4 the middle estimate is 1.1-fold (0.04 log units) below the measured one; measured number inside the range.
By their numbers in this assay, from the lowest: compounds 1, 4, 3 and 2 (each within the scatter of the next).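

In this assay, 2-methylphenyl at this position stays within the scatter of all three earlier groups (a 1.8-fold higher number from compound 1 to compound 4 (0.26 log units; within the scatter)), (a 1.1-fold lower number from compound 3 to compound 4 (0.03 log units; within the scatter)), and even a single added methyl on the phenyl ring changes nothing measurable (a 1.1-fold lower number from compound 2 to compound 4 (0.04 log units; within the scatter)). So 4-cyanophenyl, phenyl, 3,5-dimethylphenyl and 2-methylphenyl cannot be told apart on this read-out. Nothing available here offers a reason for this. Still open, on these data alone, is whether an amine or a carboxylic acid on this ring, or a longer chain in its place, would move the number beyond the scatter.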